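The source may report more compounds than this note shows. Statements on the series, on what has been measured and on what is new or still open speak of the compounds shown alone.

Working notes on the series.

The measured set comprises three compounds sharing one core. Compound 1 `Cc1c(OCCCCOc2ccc(C(=O)O)cc2)ccc(C(=O)CC2CCCC2)c1O` carries a 4-carboxyphenyl on the outer oxygen of the chain. In an assay on HEK293 cells for positive allosteric modulation of metabotropic glutamate receptor 3 (Rattus norvegicus), read by thallium flux, with a stated time of 2.5 min (on this read-out lower numbers stand for smaller maximal responses and higher numbers for larger maximal responses), compound 1 gives 26.7%. Compound 2 `CC(=O)c1ccc(OCCCCOc2ccc(C(=O)O)cc2C)c(C)c1O` gives 25.4% in this assay, and compound 3 `CC(=O)c1ccc(OCCCCOc2ccc(F)c(C(=O)O)c2)c(C)c1O` gives 16.8%. Of the three numbers, that of compound 1 is the highest, but the gap to compound 2 and the gap to compound 3 both lie within the usual scatter, so the three read as one level rather than as an order.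

Compound 4 `Cc1c(OCCCCOc2cccc(C(=O)O)c2)ccc(C(=O)CC2CCCC2)c1O` has the same atoms as compound 1, joined differently: 3-carboxyphenyl in place of 4-carboxyphenyl on an oxygen on a saturated carbon. For the measured compounds named here, no pair among the measured compounds shows this kind of change, so no measured step guides it. Moving the carboxylic acid around the ring is expected to shift this assay little, if at all, beyond the scatter, with a slight lowering more likely than a rise. The step from compound 1 to compound 4 is expected to be a number 4.7 percentage points lower from compound 1 to compound 4 (within the scatter). Compound 4 is therefore expected to give about 22% in this assay, within a range from 10% to 35%.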

Compound 4, largest response reached (reported as percent of maximum), in percent of the reference or control that the assay uses: 92.9%
The estimate for compound 4 lay 70.9 percentage points below the measured number; measured number above the stated range.
By their numbers in this assay, from the lowest: compounds 3, 2 and 1 (each within the scatter of the next); then compound 4.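

In this assay, for the compounds shown here, the change from 4-carboxyphenyl to 3-carboxyphenyl on an oxygen on a saturated carbon gives a number 66.2 percentage points higher from compound 1 to compound 4 (beyond the scatter), the first step and one beyond the scatter. Both compounds have the same atoms, so at this place the way the carboxyphenyl is joined can by itself carry a large change in maximal response, something the earlier values, which read as one level, could not show. Nothing at hand accounts for the size of this step, and it rests on this single pair.

Compounds 2 and 3 each differ from compound 4 in more than one place, so the compounds shown do not tell whether the higher response of compound 4 depends on the rest of its structure, and compound 3, at 16.8%, cannot be read as a test of this change. Also open, on these data alone, is how the response at this place would change with an amide or a tetrazole in place of the carboxylic acid, or with a longer chain between the two oxygens.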